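The compounds below may be only part of what the source reports. "The series", "measured", "known", "first", "only" and "open" are said of these compounds alone.

Of the compounds shown here, three sharing one core have been tested in an assay on membranes from brain for binding affinity to adenosine receptor A1 (Rattus norvegicus), read by radioligand binding, tested at 20 uM; on this read-out lower numbers stand for less inhibition and higher numbers for more inhibition at the one concentration tested (going by the name of the read-out). Compound 1, `Cn1c(=O)[nH]c2c(cnn2-c2ccccc2[N+](=O)[O-])c1=N`, gives 5% in this assay. Compound 2, `Cn1c(=O)[nH]c2c(cnn2-c2ccc(Cl)cc2)c1=N`, gives 37%, and compound 3, `Cn1c(=O)[nH]c2c(cnn2-c2cc(Cl)ccc2Cl)c1=N`, gives 1%. On these numbers compound 1 stands second highest of the three: its nearest neighbour is compound 3, whose value lies within the scatter of compound 1, so the two cannot be told apart; compound 2 lies beyond the scatter, well above compound 1.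

The next compound, compound 4, `Cn1c(=O)[nH]c2c(cnn2-c2ccccc2F)c1=N`, has not yet been measured in this assay. It differs from compound 1 in one place: fluoro in place of nitro on an aromatic carbon, on an aromatic carbon of a six-membered aromatic ring of carbon only, ortho to a large group. Among the compounds with values here, no step between measured compounds covers this change, so nothing shows directly what fluoro in place of nitro does here. With compound 1 at 5% and compound 3 at 1%, a small upward step is expected, likely within the scatter, and compound 4 is estimated at 14%, between 0% and 35%, meaning an expected step of a number 9 percentage points higher from compound 1 to compound 4 (within the scatter).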

Compound 4, a percentage reported as inhibition, at one concentration (the size of the read-out at that concentration, not a potency): 8%
Compound 4: middle estimate off by 6 percentage points, on the high side, within the range that was stated.
By their numbers in this assay, from the lowest: compounds 3, 1 and 4 (each within the scatter of the next); then compound 2.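

In this assay, within the data shown here, the first direct reading of fluoro in place of nitro on this aromatic carbon, ortho to a large group, is a number 3 percentage points higher from compound 1 to compound 4 (within the scatter). Going from the three heavy atoms of nitro to the single heavy atom of fluoro, and from a group with hydrogen-bond acceptors to one without, therefore leaves compound 1 and compound 4 indistinguishable in this assay. Nothing available explains why this exchange leaves the reading within the scatter.

Going by these compounds, whether an amine, a methoxy group or a carboxylic acid on this same carbon would stand apart from compound 1 and compound 4 remains open. So does whether fluoro in place of nitro would give a similar step on another carbon of the ring, or on a different core.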